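Thioether benzamides: from compound 1 to compound 3

This account rests on a few compounds, and the source may have more. Where it says the series, first, only, none or still open, it means among the compounds named here.

- Compound 1 `COc1ccc(SCc2ccc(C(=O)Nc3ccccc3N)cc2)cc1`: 3010 nM
- Compound 2 `COc1ccc(SCc2ccc(C(=O)Nc3ccccc3N)cc2)cc1OC`: 4420 nM

Both values come from a functional assay on A-375 cells (Homo sapiens) for antiproliferative activity, read by CCK-8 assay, with a stated time of 72 h; a lower number here means a stronger inhibitor, a higher number a weaker inhibitor. Compound 1 has only compound 2 as a neighbour on these numbers, and the two cannot be separated: the step is a 1.5-fold higher number from compound 1 to compound 2 (0.17 log units; within the scatter). That step places methoxy in place of hydrogen on an aromatic carbon.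

Compound 3 `Nc1ccccc1NC(=O)c1ccc(CSCCc2ccccc2)cc1` is not yet measured. Its change from the core of compound 1 is phenethyl in place of 4-methoxyphenyl on a sulfur. Going by the values given here, this swaps the aryl group on sulfur for phenethyl, a larger kind of change than the measured step, and no measured pair makes such a replacement. The step to compound 2 therefore bears on it only loosely. It shows that one added methoxy left the reading in this assay within the scatter, and it gives no direction for the loss of the 4-methoxyphenyl group.

No step beyond the scatter is expected, though with wide uncertainty, and the expected step is a 1.2-fold higher number from compound 1 to compound 3 (0.07 log units; within the scatter). Compound 3 is estimated at 3500 nM, with an expected range of 1300 nM to 9500 nM.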

Compound 3, half-maximal inhibitory concentration: 2860 nM
Compound 3: middle estimate off by 1.2-fold (0.09 log units), on the high side; the measured number falls inside the stated range.
By their numbers in this assay, from the lowest: compounds 3, 1 and 2 (each within the scatter of the next).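

The thioether position now has a test of more than ring decoration: with phenethyl in place of 4-methoxyphenyl on a sulfur, this assay gives a 1.1-fold lower number from compound 1 to compound 3 (0.02 log units; within the scatter). The step removes the 4-methoxyphenyl group entirely, including its single hydrogen-bond acceptor, and brings in a group with the same count of 8 heavy atoms and no hydrogen-bond acceptor, yet the two compounds cannot be separated by this read-out. For this pair, then, the 4-methoxyphenyl group is not needed to keep the reading at this level, a broader statement than the earlier methoxy step could support, although no measurement on hand explains why the two groups read alike.

Every group shown on the sulfur still carries a six-membered aromatic ring of carbon only, so it remains open how an amine, a carboxylic acid or a plain alkyl chain would read there. The sulfur is also constant across the compounds shown, which leaves open what a sulfone or an ether oxygen in its place would do.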